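This account rests on a few compounds, and the source may have more. Where it says the series, first, only, none or still open, it means among the compounds named here.

The study concerns binding at an assay on isolated protein for binding affinity to Adrenergic receptor alpha-1 (Rattus norvegicus), read by radioligand binding, in the presence of a further agent that is not named here; on this read-out higher numbers stand for weaker inhibition and lower numbers for stronger inhibition. Compound 1 `Clc1cccc2c1C=C(CC1CN=CN1)CC2` gives 398 nM. Compound 2 `Cc1ccc2c(c1)C=C(CC1CN=CN1)CC2` has a core that differs from that of compound 1 in a way that is not broken down here; in this assay compound 2 gives 398 nM, and the two numbers stand level at the digits given, so no order between them can be drawn. Compound 3 `NC1=NCC(CC2=Cc3c(Cl)cccc3CC2)O1` carries a group of 6 heavy atoms (3 carbon, 2 nitrogen, 1 oxygen; one five-membered non-aromatic ring with 2 hetero atoms) in place of a group of 5 heavy atoms (3 carbon, 2 nitrogen; one five-membered non-aromatic ring with 2 hetero atoms), on a saturated chain carbon bound to a double-bonded ring carbon, and in this assay compound 3 gives 316 nM. The step of a 1.3-fold lower number from compound 1 to compound 3 (0.10 log units; within the scatter) therefore lies inside the scatter of repeated measurements of this kind.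

Compound 4 `Cc1ccc2c(c1)C=C(CC1CN=C(N)O1)CC2` has not yet been measured. It stands to compound 2 as compound 3 stands to compound 1: the change is a group of 6 heavy atoms (3 carbon, 2 nitrogen, 1 oxygen; one five-membered non-aromatic ring with 2 hetero atoms) in place of a group of 5 heavy atoms (3 carbon, 2 nitrogen; one five-membered non-aromatic ring with 2 hetero atoms), on a saturated chain carbon bound to a double-bonded ring carbon, the same change at the same place, now made on the core of compound 2. Only one measured instance of this change exists among the compounds shown, and it is the step of a 1.3-fold lower number from compound 1 to compound 3 (0.10 log units; within the scatter). The expectation for compound 4 rests on that single step and on compound 2 sharing its value of 398 nM with compound 1. On that basis compound 4 is expected to give 316 nM in this assay, with the range estimated to run from 160 nM to 630 nM. This corresponds to an expected step of a 1.3-fold lower number from compound 2 to compound 4 (0.10 log units; within the scatter), which would again fall within the scatter. The measured number for compound 4 will show whether the change behaves alike on both cores.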

Compound 4, inhibition constant: 251 nM
Beside the measured number, compound 4's estimate is 1.3-fold (0.10 log units) above it; low and high end bracket the measured number.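

In this assay, the new step, a 1.6-fold lower number from compound 2 to compound 4 (0.20 log units; within the scatter), gives no readable difference between the two groups on the core of compound 2. The two cores agree on this change: the same change on two cores in this assay, a 1.3-fold lower number (0.10 log units; within the scatter) from compound 1 to compound 3 and a 1.6-fold lower number (0.20 log units; within the scatter) from compound 2 to compound 4, 1.3-fold (0.10 log units) apart, within the scatter of two such steps. This shows that, on these two cores, the change leaves the number within the scatter each time, so the result on the core of compound 1 carried over to the core of compound 2; it does not show that the group of 6 heavy atoms binds better or worse than the group of 5 heavy atoms, and one pair of steps cannot speak for other cores in the series.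

The compounds shown leave open whether a larger difference would appear with another group at this place, such as a simple amine or a carboxylic acid in place of either ring, or with a longer chain joining the ring to the core. They also leave open whether the change would stay this small on a core bearing a different group, such as a methoxy or a nitrile, in place of the chlorine of compound 1 or the methyl of compound 2.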